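The compounds below may be only part of what the source reports. "The series", "measured", "known", "first", "only" and "open" are said of these compounds alone.

Within the data shown here, compound 2 `Cc1cccc(Cl)c1C(=O)NC(CCN(C)C)c1ccc(Cl)cc1` gives 105% in an assay on NIH3T3 cells with Urotensin-2 receptor (Homo sapiens) as the target (on this read-out lower numbers stand for smaller maximal responses and higher numbers for larger maximal responses), and stands lowest of the two numbers available; the only neighbour, compound 1 `Cc1ccc(C)c(C(=O)NC(CCN(C)C)c2ccc(Cl)cc2)c1`, gives 164%, and the step of a number 59 percentage points lower from compound 1 to compound 2 (beyond the scatter) was large. Compound 3 `Cc1ccccc1NC(=O)NC(CCN(C)C)c1ccc(Cl)cc1` has not been measured. It differs from compound 2 by (2-methylphenyl)amino in place of 2-chloro-6-methylphenyl on a carbonyl carbon. Among the measured compounds shown here, the one measured step changed the aryl group on the carbonyl carbon, not the kind of link to it, so it bears only loosely on this change, and no step beyond the scatter is expected: a number 5 percentage points higher from compound 2 to compound 3 (within the scatter). Compound 3 is estimated at 110%, ranging from 50% to 170%.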

Compound 3, largest response reached (reported as efficacy), in percent of the reference or control that the assay uses: 175%
Compound 3: middle estimate off by 65 percentage points, on the low side; measured number above the stated range.
By their numbers in this assay, from the lowest: compound 2; then compound 1; then compound 3.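

On this carbonyl carbon, the aryl groups are not the only source of large shifts in this assay: replacing 2-chloro-6-methylphenyl with (2-methylphenyl)amino gives a number 70 percentage points higher from compound 2 to compound 3 (beyond the scatter) and leaves the response well raised. Replacing 2,5-dimethylphenyl with the same group gives a number 11 percentage points higher from compound 1 to compound 3 (beyond the scatter) as a smaller, modest rise, so the direction is upward from both neighbours. No evidence is available to explain these steps.

Compound 3 differs from both neighbours in its aryl substituents as well as its link, so the two contributions remain unseparated. A (2-chloro-6-methylphenyl)amino group on the same carbon would bear directly on that question.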